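A Chlorine Added to a Pendant Phenyl Ring

The compounds below may be only part of what the source reports. "The series", "measured", "known", "first", "only" and "open" are said of these compounds alone.

Measured compounds:
compound 1 `Cc1cc(O)c(C(=O)/C=C/c2ccccc2Cl)c(-c2ccccc2)c1C(=O)/C=C/c1ccccc1Cl` — "not active" (no number reported)
compound 2 `Cc1cc(O)c(C(=O)/C=C/c2ccc(F)cc2)c(-c2ccc(Br)cc2)c1C(=O)/C=C/c1ccc(F)cc1` — 22300 nM

The read-out here is a functional assay on MDA-MB-231 cells (Homo sapiens) for cytotoxicity, read by MTT assay, with a stated time of 24 h; a lower number here means a stronger inhibitor, a higher number a weaker inhibitor. In this assay compound 1 is reported as "not active" (no number reported), and no single number stands behind that word, so compound 1 cannot be placed on a scale at all; it simply falls short of any measurable effect. Compound 2 differs from compound 1 at several places at once. In this assay compound 2 gives 22300 nM. Going by the values given here, no step joins the two, so only what the two values show can be said: one weak numbered result beside one result that carries no number.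

Compound 3 `Cc1cc(O)c(C(=O)/C=C/c2ccccc2Cl)c(-c2ccc(Cl)cc2)c1C(=O)/C=C/c1ccccc1Cl` differs from compound 1 in a single place: chloro in place of hydrogen on an aromatic carbon. Among the compounds with values here, no step between measured compounds covers this change, so its size and direction in this assay are unknown; any shift could lie within the usual scatter or beyond it. Compound 3 is expected to remain weak, with an estimated value around 30000 nM and a range from 8000 nM to 120000 nM, because compound 2 gives only 22300 nM as the one numbered result here.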

Compound 3, half-maximal inhibitory concentration: 29000 nM
Compound 3: middle estimate off by 1.0-fold (0.01 log units), on the high side; the measured number falls inside the stated range.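

In this assay compound 1 stands as "not active" (no number reported) and compound 3 gives 29000 nM, so no step can be read between compound 1 and compound 3. Nothing shown here offers an explanation for these results. From the compounds shown here alone, how far the change from phenyl to 4-chlorophenyl alone shifts the measured value remains open.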